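Benzothiazole swap on the tolerated benzodioxin compound

A few compounds are considered here, and "the series" means these few. Any claim that something is new, unique, unknown or untested is made for them only; others in the source may bear on it.

In an ADME assay on HFF cells (Homo sapiens) for cytotoxicity, read by resazurin assay, with a stated time of 96 h (a higher number here means that more compound is tolerated, a lower number that less compound is tolerated), compound 2 `CN1CCN(c2ccc3nc(-c4cccc5c4OCCO5)c(-c4ccncc4)n3n2)CC1` gives > 50000 nM, which is a limit and not a number. Compound 1 `CN1CCN(c2ccc3nc(-c4ccc(-c5ccccc5)s4)c(-c4ccncc4)n3n2)CC1` gives 6800 nM and compound 3 `CN1CCN(c2ccc3nc(-c4ccc(-c5ccccc5)cc4)c(-c4ccncc4)n3n2)CC1` gives 13700 nM. Compound 4 `CN1CCN(c2ccc3nc(-c4ccc5ncsc5c4)c(-c4ccncc4)n3n2)CC1` carries 1,3-benzothiazol-6-yl in place of 2,3-dihydro-1,4-benzodioxin-5-yl on an aromatic carbon. Going by the values given here, the one measured step at this place is an at least 7.3-fold higher number from compound 1 to compound 2 (0.86 log units; beyond the scatter), beyond the scatter, and its full size is unknown. That step shows that the group here can move the number considerably, so a lower number is expected once the benzodioxin group leaves. The expected change is an at least 2.2-fold lower number from compound 2 to compound 4 (0.35 log units; beyond the scatter), a moderate step down in this assay. Compound 4 is estimated at 22000 nM, with an expected range of 9000 nM to 50000 nM.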

Compound 4, half-maximal cytotoxic concentration: 17500 nM
The estimate for compound 4 lay 1.3-fold (0.10 log units) above the measured number; the measured number falls inside the stated range.
By their numbers in this assay, from the lowest: compounds 1, 3 and 4 (each within the scatter of the next, the first and the last beyond it). At a limit, above all of these: compound 2.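

At this place on the shared core, a fused two-ring group does not by itself keep the number at the limit: in this assay the change to 1,3-benzothiazol-6-yl gives an at least 2.8-fold lower number from compound 2 to compound 4 (0.45 log units; beyond the scatter). The same group still sits clear of 5-phenylthiophen-2-yl, with a 2.6-fold higher number from compound 1 to compound 4 (0.41 log units; beyond the scatter). Compound 2 gives only a limit, so the first step has a known minimum and no full size: the limit of > 50000 nM in this assay, at which 1 of the 4 values shown sits.

Still open, from the compounds shown here alone, is how far compound 2 lies past that limit. It is also unclear how a plain phenyl or a carboxylic acid on a phenyl ring would read at this place.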